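Piperidine Carbamate to Oxadiazole Swap in GIP Receptor Agonists

This account rests on a few compounds, and the source may have more. Where it says the series, first, only, none or still open, it means among the compounds named here.

Compound 1, `CCCCOC(=O)N1CCC(Oc2ncnc3c2CCN3c2ccc(S(C)(=O)=O)cc2F)CC1`: 50.1 nM
Compound 2, `CC(C)(C)COC(=O)N1CCC(Oc2ncnc3c2CCN3c2ccc(S(C)(=O)=O)cc2F)CC1`: 39.8 nM
Compound 3, `CCSC(=O)N1CCC(Oc2ncnc3c2CCN3c2ccc(S(C)(=O)=O)cc2F)CC1`: 31.6 nM

Of the compounds shown here, three sharing one core have been tested in a functional assay on CHO-K1 cells for agonist activity at Glucose-dependent insulinotropic receptor (Homo sapiens), read by a luciferase reporter, with a stated time of 5 h; a higher number here means that more compound is needed for the effect, a lower number that less compound is needed. Compound 3 holds the lowest of the three numbers, though the steps toward it are a 1.3-fold lower number from compound 2 to compound 3 (0.10 log units; within the scatter) and a 1.6-fold lower number from compound 1 to compound 3 (0.20 log units; within the scatter), so the three stand together within the scatter. Compound 4, `CC(C)c1noc(N2CCC(Oc3ncnc4c3CCN4c3ccc(S(C)(=O)=O)cc3F)CC2)n1`, differs from compound 3 by 3-isopropyl-1,2,4-oxadiazol-5-yl in place of (ethylsulfanyl)carbonyl on an amine nitrogen in a ring. Going by the values given here, no measured step touches this change; the known steps, a 1.3-fold lower number from compound 1 to compound 2 (0.10 log units; within the scatter) and the two above, only vary the group on the carbonyl and stay within the scatter. Compound 4 is therefore expected near 40 nM, between 12 nM and 130 nM, a step of a 1.3-fold higher number from compound 3 to compound 4 (0.10 log units; within the scatter), with wide uncertainty.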

Compound 4, half-maximal effective concentration: 79.4 nM
Compound 4: the middle estimate sits 2.0-fold (0.30 log units) below what was measured, within the range that was stated.
By their numbers in this assay, from the lowest: compounds 3, 2, 1 and 4 (each within the scatter of the next, the first and the last beyond it).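

Going by these compounds alone, on the amine nitrogen in the ring, 3-isopropyl-1,2,4-oxadiazol-5-yl can take the place of a carbonyl-linked group and the compound stays active in this assay, but replacing (ethylsulfanyl)carbonyl gives the only step here beyond the scatter (a 2.5-fold higher number from compound 3 to compound 4 (0.40 log units; beyond the scatter)). Replacing neopentyloxycarbonyl (a 2.0-fold higher number from compound 2 to compound 4 (0.30 log units; within the scatter)) or butoxycarbonyl (a 1.6-fold higher number from compound 1 to compound 4 (0.20 log units; within the scatter)) stays within it, so the size of the step depends on which carbonyl group leaves. Nothing available explains this difference. On these data alone, it remains open whether a tert-butyl or cyclopropyl group in place of the isopropyl on the oxadiazole would bring the number closer to that of compound 3.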